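Aryl swap on the aromatic nitrogen: compound 3 to compound 4

This account rests on a few compounds, and the source may have more. Where it says the series, first, only, none or still open, it means among the compounds named here.

Among the measured compounds shown here, compound 3 `COc1cc2c(Oc3ccc(NC(=O)c4nn(-c5ccc(Cl)cc5)c(=O)cc4C)cc3F)ccnc2cc1OCCCN1CCN(C)CC1` gives 320 nM in a functional assay on HT-29 cells (Homo sapiens) for inhibition, read by MTT assay, with a stated time of 72 h (a lower number here means a stronger inhibitor, a higher number a weaker inhibitor), the second highest of the three numbers so far. Compound 2 `COc1cc2c(Oc3ccc(NC(=O)c4nn(-c5ccccc5C(F)(F)F)c(=O)cc4C)cc3F)ccnc2cc1OCCCN1CCN(C)CC1` gives 170 nM, within the scatter of compound 3 (a 1.9-fold higher number from compound 2 to compound 3 (0.27 log units; within the scatter)). Compound 1 `COc1cc2c(Oc3ccc(NC(=O)c4nn(-c5ccccc5C)c(=O)cc4C)cc3F)ccnc2cc1OCCCN1CCN(C)CC1` gives 3790 nM and is the weakest of the set (a 12-fold lower number from compound 1 to compound 3 (1.07 log units; beyond the scatter); a 22-fold lower number from compound 1 to compound 2 (1.35 log units; beyond the scatter)).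

Compound 4 `COc1cc2c(Oc3ccc(NC(=O)c4nn(-c5ccc(F)c(F)c5)c(=O)cc4C)cc3F)ccnc2cc1OCCCN1CCN(C)CC1` differs from compound 3 by 3,4-difluorophenyl in place of 4-chlorophenyl on an aromatic nitrogen. For the measured compounds named here, the only measured steps touching this group are a 12-fold lower number from compound 1 to compound 3 (1.07 log units; beyond the scatter) and a 1.9-fold higher number from compound 2 to compound 3 (0.27 log units; within the scatter); both exchange the whole aryl, and the second lies within the scatter. Going by the values given here, no measured step exchanges one halogenated phenyl for another, so no shift beyond the scatter is expected in this assay. Compound 4 is therefore estimated at 350 nM (range 150 nM to 900 nM), an expected step of a 1.1-fold higher number from compound 3 to compound 4 (0.04 log units; within the scatter).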

Compound 4, half-maximal inhibitory concentration: 170 nM
Beside the measured number, compound 4's estimate is 2.1-fold (0.31 log units) above it; measured number inside the range.
By their numbers in this assay, from the lowest: compounds 2, 4 and 3 (each within the scatter of the next); then compound 1.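

In this assay, a 1.9-fold lower number from compound 3 to compound 4 (0.27 log units; within the scatter) and no change at the digits printed from compound 2 to compound 4 (within the scatter), so 3,4-difluorophenyl, 4-chlorophenyl and 2-(trifluoromethyl)phenyl on the aromatic nitrogen cannot be told apart in this read-out. Of the four aryl groups, only 2-methylphenyl separates from the rest, now also with a 22-fold lower number from compound 1 to compound 4 (1.35 log units; beyond the scatter), which places compound 4 with compound 2 and compound 3 in that separation. No measured evidence accounts for this separation. Open, on these data alone, is whether the same level holds with a phenyl carrying an amine or a carboxylic acid, or with a cyclohexyl group on that nitrogen.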